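Biphenyl amides and the unmeasured fluorophenyl analogue

The compounds below may be only part of what the source reports. "The series", "measured", "known", "first", "only" and "open" are said of these compounds alone.

Measured compounds in an assay on HEK293 cells for inhibition of N-acylethanolamine-hydrolyzing acid amidase (Rattus norvegicus), read by LC-MS, with a stated time of 30 min; a higher number here means a weaker inhibitor, a lower number a stronger inhibitor: compound 1 `Cc1ccc(CCCCCCC(=O)N2CCCC2)cc1` gives 9600 nM; compound 2 `O=C(CCCCCCc1ccc(Cl)cc1)N1CCCC1` gives 34500 nM; compound 3 `Cc1ccccc1-c1ccc(CCC(=O)N2CCCC2)cc1` gives > 100000 nM.

Compound 3 sits at the limit of this assay; this is a limit, not a number (the limit of > 100000 nM in this assay, at which 1 of the 3 values shown sits). Compound 4 `O=C(CCc1ccc(-c2cccc(F)c2)cc1)N1CCCC1` differs from compound 3 by 3-fluorophenyl in place of 2-methylphenyl on an aromatic carbon. Going by the values given here, the only measured step that touches a halogen in place of a methyl on an aromatic carbon is a 3.6-fold higher number from compound 1 to compound 2 (0.56 log units; beyond the scatter), a weakening, and it lies in a different part of the molecule. Compound 4 is therefore expected to stay near the limit, with the step that the limit leaves unreadable from compound 3 to compound 4 not resolvable against a limit. The estimate for compound 4 in this assay is 150000 nM, within 40000 nM to 500000 nM.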

Compound 4, half-maximal inhibitory concentration: 1800 nM
For compound 4 the middle estimate is 83-fold (1.92 log units) above the measured one; measured number outside the range, below it.
By their numbers in this assay, from the lowest: compound 4; then compound 1; then compound 2. At a limit, above all of these: compound 3.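

In this assay, going by these compounds alone, 3-fluorophenyl in place of 2-methylphenyl on this aromatic carbon gives an at least 55-fold lower number from compound 3 to compound 4 (1.74 log units; beyond the scatter), the first readable change at this position. The halogen step elsewhere in the series, a 3.6-fold higher number from compound 1 to compound 2 (0.56 log units; beyond the scatter), went the opposite way, so its direction does not carry over to this position. The result for compound 3 is a limit, not a number: the limit of > 100000 nM in this assay, at which 1 of the 4 values shown sits.

This swap changes the substituent and its place on the ring together, and the two remain unseparated. On these data alone, how a nitrile or an amine on that ring would read stays open.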